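Compound 1 to compound 4: swapping the indazolyl group

A few compounds are considered here, and "the series" means these few. Any claim that something is new, unique, unknown or untested is made for them only; others in the source may bear on it.

Measured in a functional assay on MCF7 cells (Homo sapiens) for antiproliferative activity, read by CellTiter-Glo, with a stated time of 5 days; a higher number here means a weaker inhibitor, a lower number a stronger inhibitor
Compound 1 `CC/C(=C(/c1ccc(/C=C/C(=O)O)cc1)c1ccc2c(cnn2C)c1)c1ccccc1` gives 300 nM
Compound 2 `CC/C(=C(/c1ccc(/C=C/C(=O)O)cc1)c1ccn2nccc2c1)c1ccccc1` gives > 500 nM, a limit of the assay
Compound 3 `CC/C(=C(/c1ccc(/C=C/C(=O)O)cc1)c1ccc2nccn2c1)c1ccccc1` gives 170 nM

Compound 1 at 300 nM lies within the scatter of compound 3 at 170 nM. Compound 2 has only a limit, > 500 nM.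

Compound 4 `CC/C(=C(/c1ccc(/C=C/C(=O)O)cc1)c1ccc2cncn2c1)c1ccccc1` loses the 1-methyl-1H-indazol-5-yl group of compound 1 and carries a group of 9 heavy atoms (7 carbon, 2 nitrogen; one five-membered aromatic ring with 2 hetero atoms, one six-membered aromatic ring with 1 hetero atom) in place of a group of 10 heavy atoms (8 carbon, 2 nitrogen; one five-membered aromatic ring with 2 hetero atoms, one six-membered aromatic ring of carbon only), on a double-bonded chain carbon bound to an aromatic carbon and a double-bonded chain carbon, on the same double-bonded chain carbon.

Two swaps of the same kind bear on this change: a 1.8-fold lower number from compound 1 to compound 3 (0.25 log units; within the scatter) and an at least 1.6-fold higher number from compound 1 to compound 2 (0.22 log units; that floor lies within the scatter). Neither goes beyond the scatter, although the second is only a floor. The two entering groups do separate, with an at least 2.9-fold lower number from compound 2 to compound 3 (0.46 log units; beyond the scatter), so the range is kept wide. No step beyond the scatter is therefore expected in this assay. The estimated step is a 1.2-fold lower number from compound 1 to compound 4 (0.08 log units; within the scatter). For compound 4 the expected value is 250 nM, with an estimated range from 90 nM to 500 nM.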

Compound 4, half-maximal inhibitory concentration: > 500 nM
Compound 4 gave a limit, no number (the forecaster's own chance of this, stated with the estimate: 20%); at least 2.0-fold (0.30 log units) between middle value and limit.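

In this assay compound 4 gives > 500 nM, which is a limit of the assay and not a number. The group in compound 4 has the same heavy-atom, ring and hetero-atom counts as the group in compound 3, yet the result is an at least 2.9-fold higher number from compound 3 to compound 4 (0.46 log units; beyond the scatter), so at this double-bonded chain carbon groups with identical counts now separate in both compound 2 and compound 4, while an at least 1.6-fold higher number from compound 1 to compound 4 (0.22 log units; that floor lies within the scatter) leaves compound 4 not yet separated from compound 1. The step from compound 2 to compound 4 cannot be read, and the limit now recurs in the series: the limit of > 500 nM in this assay, at which 2 of the 4 values shown sit.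

As far as these compounds go, how far compound 2 and compound 4 lie past that limit stays open. Also open, from the compounds shown here alone, is whether an amine or a methoxy group on the group of compound 3 would keep its value.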